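Methyl Additions on Two Related Cores in Lung Cancer Cells

This account rests on a few compounds, and the source may have more. Where it says the series, first, only, none or still open, it means among the compounds named here.

Compound 1 `COc1cc(/C=C/C(=O)/C=C/c2nc3ccccc3n2C)ccc1O` is tested in a functional assay on NCI-H460 cells (Homo sapiens) for cytotoxicity, read by MTT assay, with a stated time of 48 h (on this read-out lower numbers stand for stronger inhibition and higher numbers for weaker inhibition), where compound 1 gives 7000 nM. Compound 2 `COc1cc(/C=C/C(=O)/C=C/c2nc3cc(C)ccc3n2C)ccc1O` differs from it by methyl in place of hydrogen on an aromatic carbon, and in this assay compound 2 gives 7700 nM, so the step of a 1.1-fold higher number from compound 1 to compound 2 (0.04 log units; within the scatter). Compound 3 `COc1ccc(/C=C/C(=O)/C=C/c2nc3c(C)cccc3n2C)cc1O` carries a different core; the difference between the two cores is not broken down here. In this assay compound 3 gives 25400 nM. Compound 4 `COc1ccc(/C=C/C(=O)/C=C/c2nc3c(C)c(C)ccc3n2C)cc1O` has not been measured and differs from compound 3 by methyl in place of hydrogen on an aromatic carbon. This is the same kind of change as that made from compound 1 to compound 2, but here the place is ortho to a methyl group. Because the earlier step of a 1.1-fold higher number from compound 1 to compound 2 (0.04 log units; within the scatter) lay within the scatter, a step of similar size is expected, namely a 1.1-fold higher number from compound 3 to compound 4 (0.04 log units; within the scatter). Compound 4 is therefore estimated at 28000 nM in this assay, expected to lie between 12000 nM and 65000 nM.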

Compound 4, half-maximal inhibitory concentration: 7300 nM
Compound 4: middle estimate off by 3.8-fold (0.58 log units), on the high side, outside the stated range (below it).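

In this assay, methyl in place of hydrogen on an aromatic carbon gives a 3.5-fold lower number from compound 3 to compound 4 (0.54 log units; beyond the scatter). Set beside the earlier step, this shows that the same change did not carry over at the same size from one core to the other: the same change on two cores in this assay, a 1.1-fold higher number (0.04 log units; within the scatter) from compound 1 to compound 2 and a 3.5-fold lower number (0.54 log units; beyond the scatter) from compound 3 to compound 4, 3.8-fold (0.58 log units) apart, beyond the scatter of two such steps. It does not show what sets the two steps apart, as they differ both in the core and in the place of the added methyl, here ortho to a methyl group, and two steps give no rule for the series.

As far as these compounds go, it remains open how the core of compound 1 would respond to a methyl at this same place. From the compounds shown here alone, it also remains open whether an amine or a longer alkyl chain there would follow the methyl.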